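Dimethoxy to difluoro on the carbonyl-bound ring

The source may report more compounds than this note shows. Statements on the series, on what has been measured and on what is new or still open speak of the compounds shown alone.

In a functional assay on NCI-H460 cells (Homo sapiens) for cytotoxicity, read by sulforhodamine B assay, with a stated time of 48 h, tested at 10 uM (on this read-out higher numbers stand for a weaker effect at the one concentration tested and lower numbers for a stronger effect), compound 3 `COc1ccc(C(=O)/C=C/c2cc(-c3cc(OC)c(OC)c(OC)c3)n[nH]2)cc1OC` gives -64%, the lowest of the three numbers recorded. Compound 1 `COc1cc(-c2cc(/C=C/C(=O)c3ccc(N)cc3)[nH]n2)cc(OC)c1OC` gives -32% and compound 2 `COc1cc(-c2cc(/C=C/C(=O)c3ccc(Cl)c(Cl)c3)[nH]n2)cc(OC)c1OC` gives 31% in this assay. Compound 4 `COc1cc(-c2cc(/C=C/C(=O)c3ccc(F)c(F)c3)[nH]n2)cc(OC)c1OC` differs from compound 3 in one place: 3,4-difluorophenyl in place of 3,4-dimethoxyphenyl on a carbonyl carbon. Among the compounds with values here, the steps that bear on this change are a number 95 percentage points lower from compound 2 to compound 3 (beyond the scatter) and a number 32 percentage points lower from compound 1 to compound 3 (beyond the scatter), both beyond the scatter, while a number 63 percentage points higher from compound 1 to compound 2 (beyond the scatter) shows that 3,4-dichlorophenyl gave the weakest effect of the three. A large step upward is therefore expected for compound 4, since 3,4-difluorophenyl resembles 3,4-dichlorophenyl more than 3,4-dimethoxyphenyl, though the size is uncertain. Compound 4 is estimated at 5%, within -40% to 45%, an expected step of a number 69 percentage points higher from compound 3 to compound 4 (beyond the scatter).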

Compound 4, a percentage reported as activity, at one concentration (the size of the read-out at that concentration, not a potency): -9%
For compound 4 the middle estimate is 14 percentage points above the measured one; the measured number falls inside the stated range.
By their numbers in this assay, from the lowest: compound 3; then compound 1; then compound 4; then compound 2.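

In this assay this position separates even the two halogen-bearing rings: the change to 3,4-difluorophenyl from 3,4-dichlorophenyl is a number 40 percentage points lower from compound 2 to compound 4 (beyond the scatter). Yet 3,4-difluorophenyl does not match 3,4-dimethoxyphenyl, with a number 55 percentage points higher from compound 3 to compound 4 (beyond the scatter), and it also stands apart from 4-aminophenyl, with a number 23 percentage points higher from compound 1 to compound 4 (beyond the scatter), so the four groups give four separate levels. No evidence is available here to explain these differences. The compounds shown leave open where a 4-fluorophenyl or a 3,4-dihydroxyphenyl group would fall on this scale. They also leave open whether any group on this carbonyl carbon would go beyond compound 3.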